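The compounds below may be only part of what the source reports. "The series", "measured", "known", "first", "only" and "open" are said of these compounds alone.

Compound 3 `CCOc1nc(-c2cc3ccccc3o2)cc(-c2ccc(OC)cc2)c1C#N` gives 204000 nM in a functional assay on aorta (strain Wistar) for inhibition, with Thoracic aorta (Rattus norvegicus) as the target (on this read-out higher numbers stand for weaker inhibition and lower numbers for stronger inhibition), the lowest of the three numbers; compound 1 `CCOc1nc(-c2cc3ccccc3o2)cc(-c2ccc3ccccc3c2)c1C#N` gives 423000 nM and compound 2 `CCOc1nc(-c2cc3ccccc3o2)cc(-c2ccc(Cl)cc2Cl)c1C#N` gives 442000 nM. Compound 4 `CCOc1nc(-c2cc3ccccc3o2)cc(-c2ccc(C)o2)c1C#N` carries 5-methylfuran-2-yl in place of 4-methoxyphenyl on an aromatic carbon. Within the data shown here, the steps that bear on this change are those at the same carbon: a 2.1-fold lower number from compound 1 to compound 3 (0.32 log units; beyond the scatter) and a 2.2-fold lower number from compound 2 to compound 3 (0.34 log units; beyond the scatter), both modest, while a 1.0-fold higher number from compound 1 to compound 2 (0.02 log units; within the scatter). Swaps of the aryl group at this carbon have thus moved this assay only modestly, and the 4-methoxyphenyl of compound 3 gave the lowest number. Among the measured compounds shown here, no measured step covers a five-membered ring here. A modest drift back toward the higher numbers is expected for compound 4, a 1.5-fold higher number from compound 3 to compound 4 (0.17 log units; within the scatter). Compound 4 is estimated at 300000 nM, with a range from 120000 nM to 750000 nM.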

Compound 4, half-maximal inhibitory concentration: 417000 nM
For compound 4 the middle estimate is 1.4-fold (0.14 log units) below the measured one; measured number inside the range.
By their numbers in this assay, from the lowest: compound 3; then compounds 4, 1 and 2 (each within the scatter of the next).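

In this assay the five-membered 5-methylfuran-2-yl gives a 2.0-fold higher number from compound 3 to compound 4 (0.31 log units; beyond the scatter) and so does not keep the lower number of 4-methoxyphenyl. It sits level with the other groups, with a 1.1-fold lower number from compound 2 to compound 4 (0.03 log units; within the scatter) and a 1.0-fold lower number from compound 1 to compound 4 (0.01 log units; within the scatter) as the steps, leaving 4-methoxyphenyl as the only group apart among these four. No evidence on the origin of this gap is at hand.

Still open, from the compounds shown here alone, is whether 4-aminophenyl or 4-hydroxyphenyl at this carbon would keep or extend the lower number of compound 3. Going by these compounds, the effect of a longer chain in place of the ethoxy group is also open.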